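The compounds below may be only part of what the source reports. "The series", "measured", "known", "first", "only" and "open" are said of these compounds alone.

Of the compounds shown here, three have so far been measured in a functional assay on HL-60 cells (Homo sapiens) for inhibition, read by MTT assay, with a stated time of 72 h; a higher number here means a weaker inhibitor, a lower number a stronger inhibitor. Compound 1 (`Cc1nc(-c2cccc(F)c2)c(C(=O)N2CCN(c3cccc(Cl)c3)CC2)o1`) gives 33.7 nM, compound 2 (`Cc1nc(-c2ccccc2)c(C(=O)N2CCN(c3cccc(C)c3C)CC2)o1`) gives 35 nM, and compound 3 (`COc1cc(OC)cc(N2CCN(C(=O)c3onc(C)c3-c3ccccc3)CC2)c1`) gives 152 nM. Compound 2 thus stands level with compound 1, the two lying within the scatter of each other, while compound 3 has a higher number than compound 2, a gap beyond the scatter. Among the measured compounds shown here, no two of these measured compounds differ in one place only, so the data offer no direct step to lean on.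

The next compound, compound 4 (`Cc1nc(-c2ccccc2)c(C(=O)N2CCN(c3ccccc3Cl)CC2)o1`), differs from compound 2 in a single place: 2-chlorophenyl in place of 2,3-dimethylphenyl on an amine nitrogen in a ring. The closest guide is compound 1, which also carries a chlorophenyl group on that nitrogen and gives 33.7 nM, although it differs from compound 4 elsewhere as well. On that basis, only a small change is expected. In this assay the expected step is a 1.3-fold higher number from compound 2 to compound 4 (0.11 log units; within the scatter), slightly toward a weaker inhibitor and not beyond the scatter. Compound 4 is estimated at 45 nM, with an expected range from 18 nM to 120 nM.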

Compound 4, half-maximal inhibitory concentration: 124 nM
The estimate for compound 4 lay 2.8-fold (0.44 log units) below the measured number, and the stated range ends below it.
By their numbers in this assay, from the lowest: compounds 1 and 2 (each within the scatter of the next); then compounds 4 and 3 (each within the scatter of the next).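

In this assay, among the compounds shown here, the pair formed by compound 2 and compound 4 gives the first direct reading of a single change, and it shows that the group on this amine nitrogen in a ring is not indifferent: replacing 2,3-dimethylphenyl with 2-chlorophenyl gives a 3.5-fold higher number from compound 2 to compound 4 (0.55 log units; beyond the scatter), a move toward a weaker inhibitor. The two groups match in what is counted here, each having one six-membered aromatic ring of carbon only, no hydrogen-bond donors or acceptors and no net charge, so those counts do not separate them, and they differ in their substituents and in having 8 and 7 heavy atoms. Nothing available explains the size or direction of this step.

For the compounds shown here, the single step swaps both methyl groups for one chlorine, so it cannot show whether the loss of the methyl groups, the arrival of the chlorine, or both together account for the change. The compounds shown also leave open how an unsubstituted phenyl, or a phenyl bearing a nitrile or trifluoromethyl group, would behave on this nitrogen with the rest of compound 2 unchanged.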